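The source may report more compounds than this note shows. Statements on the series, on what has been measured and on what is new or still open speak of the compounds shown alone.

Within the data shown here, compound 1 `Oc1cccc(-c2cc(-c3ccc(Cl)cc3)nc(-c3ccco3)c2)c1` gives 10500 nM in a functional assay on T47D cells (Homo sapiens) for cytotoxicity, read by CCK-8 assay and cell counting, with a stated time of 2 days (a lower number here means a stronger inhibitor, a higher number a weaker inhibitor), the lowest of the three numbers so far, though compound 3 `Oc1cccc(-c2cc(-c3ccccc3)nc(-c3ccc(Cl)cc3)c2)c1` with 11300 nM and compound 2 `Oc1cccc(-c2cc(-c3ccc(Cl)cc3)nc(-c3cccnc3)c2)c1` with 18100 nM both sit within the scatter of it. Compound 4 `Oc1ccc(-c2cc(-c3ccc(Cl)cc3)nc(-c3ccco3)c2)cc1` differs from compound 1 in one place: 4-hydroxyphenyl in place of 3-hydroxyphenyl on an aromatic carbon. The measured steps all alter a different group: a 1.7-fold higher number from compound 1 to compound 2 (0.24 log units; within the scatter), a 1.1-fold higher number from compound 1 to compound 3 (0.03 log units; within the scatter) and a 1.6-fold lower number from compound 2 to compound 3 (0.20 log units; within the scatter), each within the scatter, and none changes the 3-hydroxyphenyl group, so they offer no direct guide to this move. Without such a guide, the expected step of no change at the digits printed from compound 1 to compound 4 (within the scatter) is none beyond the scatter. Compound 4 is therefore estimated at 10500 nM in this assay, with a range of 4000 nM to 28000 nM.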

Compound 4, half-maximal inhibitory concentration: 6260 nM
Beside the measured number, compound 4's estimate is 1.7-fold (0.22 log units) above it; low and high end bracket the measured number.
By their numbers in this assay, from the lowest: compounds 4, 1, 3 and 2 (each within the scatter of the next, the first and the last beyond it).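

Among these compounds, the group opposite the ring nitrogen is changed here for the first time: in this assay, 4-hydroxyphenyl in place of 3-hydroxyphenyl gives a 1.7-fold lower number from compound 1 to compound 4 (0.22 log units; within the scatter). These two compounds have the same atoms joined differently, yet this assay does not separate them, so either hydroxyphenyl group fits at this position on this evidence. No available evidence bears on the reason for this small step. Still open, going by these compounds, is how a methoxy group or an amine in place of the hydroxyl on this phenyl ring would read. Also open, on these data alone, is whether 4-hydroxyphenyl would give the same result alongside pyridin-3-yl instead of furan-2-yl.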